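This account rests on a few compounds, and the source may have more. Where it says the series, first, only, none or still open, it means among the compounds named here.

Compound 1, `OC[C@H]1O[C@@H](n2cnc3c(NCc4ccccc4F)ncnc32)[C@H](O)[C@@H]1O`: 4600 nM
Compound 2, `OC[C@H]1O[C@@H](n2cnc3c(NCc4cccc(F)c4)ncnc32)[C@H](O)[C@@H]1O`: 4000 nM
Compound 3, `COc1cccc(CNc2ncnc3c2ncn3[C@@H]2O[C@H](CO)[C@@H](O)[C@H]2O)c1`: 7600 nM

These three compounds share one core and differ only in the aromatic ring carried on a saturated chain carbon bound to a nitrogen on an aromatic ring. All were tested in a functional assay on CCRF-CEM cells (Homo sapiens) for antiproliferative activity, with a stated time of 72 h; on this read-out higher numbers stand for weaker inhibition and lower numbers for stronger inhibition. Compound 2 gives the lowest of the three numbers, yet the step of a 1.2-fold lower number from compound 1 to compound 2 (0.06 log units; within the scatter) and the step of a 1.9-fold higher number from compound 2 to compound 3 (0.28 log units; within the scatter) both lie within the usual scatter, as does a 1.7-fold higher number from compound 1 to compound 3 (0.22 log units; within the scatter), so no real ordering among the three can be claimed.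

Compound 4, `COc1ccc(CNc2ncnc3c2ncn3[C@@H]2O[C@H](CO)[C@@H](O)[C@H]2O)c(OC)c1`, has not yet been measured. It differs from compound 2 as follows: 2,4-dimethoxyphenyl in place of 3-fluorophenyl on a saturated chain carbon bound to a nitrogen on an aromatic ring. For the measured compounds named here, two measured steps bear on this change. The step of a 1.9-fold higher number from compound 2 to compound 3 (0.28 log units; within the scatter) swapped methoxy for fluoro on the aromatic ring, and the step of a 1.7-fold higher number from compound 1 to compound 3 (0.22 log units; within the scatter) swapped a methoxyphenyl for a fluorophenyl; both stayed within the scatter. The change to compound 4 is larger than either of these, since the entering group carries more heavy atoms and acceptors, so the uncertainty is wider, but nothing seen so far points to a step beyond the scatter in either direction.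

Compound 4 is therefore expected to give about 6500 nM in this assay, estimated to fall between 2800 nM and 15000 nM. This estimate corresponds to an expected 1.6-fold higher number from compound 2 to compound 4 (0.21 log units; within the scatter).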

Compound 4, half-maximal inhibitory concentration: > 166000 nM
Compound 4: no number, only a limit; the forecaster's own chance of this, stated with the estimate: 10%; middle value at least 25-fold (1.40 log units) away from the limit.
By their numbers in this assay, from the lowest: compounds 2, 1 and 3 (each within the scatter of the next). At a limit, above all of these: compound 4.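

Compound 4 has no number in this assay, only a limit: the limit of > 166000 nM in this assay, at which 1 of the 4 values shown sits. All three steps to it lie beyond the scatter: an at least 41-fold higher number from compound 2 to compound 4 (1.61 log units; beyond the scatter), an at least 36-fold higher number from compound 1 to compound 4 (1.55 log units; beyond the scatter) and an at least 21-fold higher number from compound 3 to compound 4 (1.33 log units; beyond the scatter). The earlier swaps among 2-fluorophenyl, 3-fluorophenyl and 3-methoxyphenyl on a saturated chain carbon bound to a nitrogen on an aromatic ring all stayed within the scatter, so this place is not indifferent to what the ring carries, and the compound with 3-methoxyphenyl gave no warning of the large step seen with 2,4-dimethoxyphenyl.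

The compounds shown cannot say why the step is so large, or whether one of the two methoxy groups alone would produce it or both are needed. They also leave open how a ring carrying an amine or a carboxylic acid, or a longer chain holding the ring, would behave at this place.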